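This account rests on a few compounds, and the source may have more. Where it says the series, first, only, none or still open, it means among the compounds named here.

Working notes on the series. In a functional assay on MCF7 cells (Homo sapiens) for antiproliferative activity, read by MTT assay (on this read-out higher numbers stand for weaker inhibition and lower numbers for stronger inhibition), compound 2 `CCOC(=O)/C=N/c1cnc(Nc2ccc(S(N)(=O)=O)cc2)nc1NC1CCCC1` gives 42200 nM, and compound 3 `NS(=O)(=O)c1ccc(Nc2ncc(/N=C/c3ccccc3)c(NC3CCCC3)n2)cc1` gives 39100 nM. The step of a 1.1-fold lower number from compound 2 to compound 3 (0.03 log units; within the scatter) corresponds to phenyl in place of ethoxycarbonyl on a carbon double-bonded to nitrogen. Compound 1 `CN1CCN(c2ccc(Nc3ncc(/N=C/c4ccc(C(F)(F)F)cc4)c(NC4CCCC4)n3)cc2)CC1` carries a trifluoromethyl on its benzylidene ring together with a different aryl amine end; in this assay compound 1 reaches only a limit, > 100000 nM. Among the measured compounds shown here, compound 3 thus holds the lower of the two numbers given, with compound 2 within the scatter of it, and the one further value is a limit (the limit of > 100000 nM in this assay, at which 1 of the 3 values shown sits).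

Compound 4 `NS(=O)(=O)c1ccc(Nc2ncc(/N=C/c3ccc(C(F)(F)F)cc3)c(NC3CCCC3)n2)cc1` differs from compound 3 by trifluoromethyl in place of hydrogen on an aromatic carbon, para to a large group; cut one bond further out this reads phenyl to 4-(trifluoromethyl)phenyl. For the measured compounds named here, no measured pair isolates this change. Going by the values given here, the single measured step, from compound 2 to compound 3, concerns another position and sits within the scatter; compound 1 combines the trifluoromethyl with a different aryl end, so it does not isolate the change either. For this assay a small expected step of a 1.5-fold higher number from compound 3 to compound 4 (0.19 log units; within the scatter) is taken, leaning toward weaker inhibition but not beyond the scatter with confidence. Compound 4 is therefore estimated at 60000 nM, within 20000 nM to 200000 nM.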

Compound 4, half-maximal inhibitory concentration: > 100000 nM
Compound 4 gave a limit, no number; the forecaster's own chance of this, stated with the estimate: 25%; middle value at least 1.6-fold (0.22 log units) from the limit.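

Trifluoromethyl in place of hydrogen on an aromatic carbon, para to a large group, is now isolated in a single pair, and in this assay it gives an at least 2.5-fold higher number from compound 3 to compound 4 (0.40 log units; beyond the scatter), whereas the one earlier step, a 1.1-fold lower number from compound 2 to compound 3 (0.03 log units; within the scatter), stayed within the scatter. The substituent on the carbon double-bonded to nitrogen therefore does register in this assay once the ring carries the trifluoromethyl, as an at least 2.3-fold higher number from compound 2 to compound 4 (0.37 log units; beyond the scatter) also shows, so the phenyl and ethoxycarbonyl values being close does not extend to 4-(trifluoromethyl)phenyl. Compound 4 now shares its limit with compound 1, and the step between these two cannot be read, so the sulfamoyl and 4-methylpiperazin-1-yl ends cannot be ranked in the trifluoromethyl pair: the limit of > 100000 nM in this assay, at which 2 of the 4 values shown sit.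

Going by these compounds, the true size of the trifluoromethyl step remains unknown, since compound 4 gives a limit and not a number. Open too, on these data alone, is whether a methoxy, a chlorine, an amine or a carboxylic acid on the same aromatic carbon would stay within the scatter of compound 3 or likewise move the number toward the limit.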